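Aryl-for-alkyl exchange at the oxalamide nitrogen: next variant

The source may hold more compounds than are shown below. What is called first, only, known or untested is meant among the compounds shown, and "the series" means these compounds.

The series shares a core carrying an aspartate-derived acid and a tetrafluorophenoxymethyl ketone, varied only at the saturated chain carbon bound to an amide-type nitrogen. Compound 1 `C[C@H](NC(=O)C(=O)NCCC1CCCC1)C(=O)N[C@@H](CC(=O)O)C(=O)COc1c(F)c(F)cc(F)c1F` gives 11 nM in a functional assay on Jurkat cells (Homo sapiens); a higher number here means a weaker inhibitor, a lower number a stronger inhibitor. Compound 2 `C[C@H](NC(=O)C(=O)NCC1CCCCC1)C(=O)N[C@@H](CC(=O)O)C(=O)COc1c(F)c(F)cc(F)c1F` gives 19 nM, and compound 3 `Cc1ccccc1CNC(=O)C(=O)N[C@@H](C)C(=O)N[C@@H](CC(=O)O)C(=O)COc1c(F)c(F)cc(F)c1F` gives 52 nM. Compound 3 thus has the highest number of the three: the step of a 4.7-fold higher number from compound 1 to compound 3 (0.67 log units; beyond the scatter) and the step of a 2.7-fold higher number from compound 2 to compound 3 (0.44 log units; beyond the scatter) both lie beyond the scatter, whereas the step of a 1.7-fold higher number from compound 1 to compound 2 (0.24 log units; within the scatter) does not.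

Compound 4 `C[C@H](NC(=O)C(=O)NCc1cc(Cl)ccc1Cl)C(=O)N[C@@H](CC(=O)O)C(=O)COc1c(F)c(F)cc(F)c1F` is not yet measured. Relative to compound 3 the change is 2,5-dichlorophenyl in place of 2-methylphenyl on a saturated chain carbon bound to an amide-type nitrogen. Going by the values given here, both measured steps into compound 3 replace a saturated group with an aromatic one; no measured step exchanges one substituted phenyl for another, so the size of the present step has no direct precedent. The two aryl-for-alkyl steps were modest, and the exchange of substituents on an aromatic ring that already sits at the same place is expected to move this assay less than that, in either direction, most likely within the scatter.

For compound 4 a value of 45 nM is estimated, within a range of 15 nM to 140 nM, which corresponds to an expected step of a 1.2-fold lower number from compound 3 to compound 4 (0.06 log units; within the scatter).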

Compound 4, half-maximal inhibitory concentration: 4.3 nM
Beside the measured number, compound 4's estimate is 10-fold (1.02 log units) above it; measured number below the stated range.
By their numbers in this assay, from the lowest: compound 4; then compounds 1 and 2 (each within the scatter of the next); then compound 3.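

In this assay, exchanging one substituted phenyl for another at the saturated chain carbon bound to an amide-type nitrogen proves to be no minor move: 2,5-dichlorophenyl in place of 2-methylphenyl gives a 12-fold lower number from compound 3 to compound 4 (1.08 log units; beyond the scatter), the largest step in the set. The aromatic group therefore does not by itself give the higher number seen with 2-methylphenyl, since the dichlorinated ring also improves on both saturated groups, with a 4.4-fold lower number from compound 2 to compound 4 (0.65 log units; beyond the scatter) and a 2.6-fold lower number from compound 1 to compound 4 (0.41 log units; beyond the scatter), which makes compound 4 the strongest inhibitor of the four in this assay. Nothing on hand accounts for the gain, so the result stands here as an observation without an explanation.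

The compounds shown leave open whether the gain needs both chlorine atoms or whether a single chlorine on the phenyl would carry it, and how far the 2-methyl group of compound 3 holds the number up, a question that a plain phenyl or 2,5-dimethylphenyl would address. Also open, from the compounds shown here alone, is whether the 2,5-dichlorophenyl keeps its value on a longer chain to the amide-type nitrogen.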